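Cytotoxicity series: ethyl in place of chloro

The compounds below may be only part of what the source reports. "The series", "measured", "known", "first", "only" and "open" are said of these compounds alone.

Measured compounds in an ADME assay on NCM460 cells (Homo sapiens) for cytotoxicity, read by MTT assay, with a stated time of 72 h; on this read-out higher numbers stand for weaker inhibition and lower numbers for stronger inhibition:
compound 1 `O=C(NCC1CCCCC1)c1cccc(/C=C2\CC(=O)N(c3ccccc3)C2=O)c1` — > 100000 nM, a limit of the assay, not a number
compound 2 `Cc1ccc(NC(=O)c2cccc(/C=C3\CC(=O)N(c4ccccc4)C3=O)c2)cc1` — > 100000 nM, a limit of the assay, not a number
compound 3 `O=C(Nc1ccc(Cl)cc1)c1cccc(/C=C2\CC(=O)N(c3ccccc3)C2=O)c1` — > 100000 nM, a limit of the assay, not a number

Compound 3 stands at the limit of > 100000 nM in this assay, at which 3 of the 3 values shown sit, and both other values of the series sit at that same limit, so no number places compound 3 above or below compound 1 or compound 2. Accordingly the steps a step that the two limits leave unreadable from compound 1 to compound 2, a step that the two limits leave unreadable from compound 1 to compound 3 and a step that the two limits leave unreadable from compound 2 to compound 3 are all unreadable in size and direction.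

Compound 4 `CCc1ccc(NC(=O)c2cccc(/C=C3\CC(=O)N(c4ccccc4)C3=O)c2)cc1` differs from compound 3 by ethyl in place of chloro on an aromatic carbon. Among the measured compounds shown here, the only measured step on the same aromatic carbon, a step that the two limits leave unreadable from compound 2 to compound 3, exchanges methyl for chloro and reads as unreadable; it shows only that both substituents leave the value at the limit. For the measured compounds named here, no measured step therefore supplies a size or a direction for ethyl in place of chloro; what the series shows is that every amide-nitrogen variant so far stays at the limit.

In this assay compound 4 is expected at 150000 nM, in the range 50000 nM to 500000 nM, most likely reported again only as a limit. The step that the limit leaves unreadable from compound 3 to compound 4 that this estimate means is expected to stay within the scatter.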

Compound 4, half-maximal inhibitory concentration: > 100000 nM
Compound 4: no number, only a limit; the forecaster's own chance of this, stated with the estimate: 85%; the middle value lies beyond the limit too.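

In this assay compound 4 gives > 100000 nM, a limit of the assay and not a number. No new step can be read: those linking compound 4 with compound 1, compound 2 and compound 3 stay unreadable in size and direction, and the series offers one shared reading: the limit of > 100000 nM in this assay, at which 4 of the 4 values shown sit.

The compounds shown leave open whether any amide-nitrogen variant yields an actual number, and how these four compare with one another.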